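A Halogenated Side Group Changes on Compound 2

The source may hold more compounds than are shown below. What is called first, only, known or untested is meant among the compounds shown, and "the series" means these compounds.

In an ADME assay on L1210/0 cells (Mus musculus) for cytotoxicity, with a stated time of 48 h (a higher number here means a weaker inhibitor, a lower number a stronger inhibitor), compound 1 (`CC1(C)[C@@H](Cn2cnc3c(O)nc(N)nc32)CC[C@@]1(C)CO`) gives > 200000 nM as a limit of the assay, not a number. For the measured compounds named here, compound 2 (`O=c1[nH]c(=O)n([C@H]2C[C@H](O)[C@@H](CO)O2)cc1/C=C/I`) gives 63900 nM as the only actual number so far. In compound 3 (`C=C(Cl)c1cn([C@H]2C[C@H](O)[C@@H](CO)O2)c(=O)[nH]c1=O`) 1-chloroethenyl stands in place of 2-iodoethenyl on an aromatic carbon (1-chloroethenyl in place of 2-iodoethenyl on an aromatic carbon). Going by the values given here, no measured pair of compounds shows the outcome of such a swap. The expected change is therefore modest and toward weaker inhibition (a 1.4-fold higher number from compound 2 to compound 3 (0.15 log units; within the scatter)). For compound 3 the expected value is 90000 nM (estimated range 30000 nM to 200000 nM).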

Compound 3, half-maximal inhibitory concentration: 1660 nM
For compound 3 the middle estimate is 54-fold (1.73 log units) above the measured one; the measured number lies below the stated range.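

In this assay, the side group at this aromatic carbon matters a great deal: 1-chloroethenyl in place of 2-iodoethenyl gives a 38-fold lower number from compound 2 to compound 3 (1.59 log units; beyond the scatter). The two groups match in heavy-atom count and each has one double bond, yet the swap still moves the value far beyond the scatter. Nothing measured here explains this step.

The halogen and its place on the side group change together, so the compounds shown cannot separate the two. From the compounds shown here alone, how 2-chloroethenyl or an amine would behave at this position remains open.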